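Swapping the Aryl Group for a Methylpiperazine

The source may report more compounds than this note shows. Statements on the series, on what has been measured and on what is new or still open speak of the compounds shown alone.

Compound 1 `C=Cc1ccc(-c2cc(C)c3ncc(CSCCc4ccccc4)n3c2)cc1` in an ADME assay on HEL cells (Homo sapiens) for cytotoxicity, with a stated time of 3 days (a higher number here means that more compound is tolerated, a lower number that less compound is tolerated), gives 20 ug/mL. Compound 2 `Cc1cc(N2CCCC2)cn2c(CSCCc3ccccc3)cnc12` in this assay gives 20 ug/mL, and the step of no change at the digits printed from compound 1 to compound 2 (within the scatter) shows nothing beyond the scatter, so compound 1 stands level with compound 2. Compound 3 `Cc1cc(N2CCN(C)CC2)cn2c(CSCCc3ccccc3)cnc12` differs from compound 1 by 4-methylpiperazin-1-yl in place of 4-vinylphenyl on an aromatic carbon. Among the measured compounds shown here, the only measured step that bears on replacing the 4-vinylphenyl with a nitrogen-linked saturated ring is the one to compound 2, which was flat, so no step beyond the scatter is expected in this assay. Compound 3 is therefore estimated at 20 ug/mL, in a range from 10 ug/mL to 40 ug/mL, an expected step of no change at the digits printed from compound 1 to compound 3 (within the scatter).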

Compound 3, minimum cytotoxic concentration: 20 ug/mL
Estimate against measurement, compound 3: no gap at the digits printed, and the stated range covers the measured number.
By their numbers in this assay, from the lowest: compounds 1, 2 and 3 (each within the scatter of the next).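

Placing the 4-methylpiperazin-1-yl group on this aromatic carbon gives no change at the digits printed from compound 1 to compound 3 (within the scatter) in this assay and, set against the pyrrolidin-1-yl group, no change at the digits printed from compound 2 to compound 3 (within the scatter) as well. The flat reading therefore no longer rests on compound 2 alone: it holds across the 4-vinylphenyl group and two saturated nitrogen-linked rings, one of them with 2 hetero atoms. Nothing available explains this flat reading. On these data alone, it remains open whether a carboxylic acid or a primary amine on this carbon would shift the reading.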